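Replacing a Benzyloxy Tail with a Methyl Ester

The source may report more compounds than this note shows. Statements on the series, on what has been measured and on what is new or still open speak of the compounds shown alone.

Three compounds have been measured in a functional assay on DLD-1 cells (Homo sapiens) for antiproliferative activity, read by CellTiter-Glo, with a stated time of 72 h; a lower number here means a stronger inhibitor, a higher number a weaker inhibitor:

compound 1, `Cc1ccc(-c2ccccc2S(=O)(=O)N2CCC(N3CCC(C)CC3)CC2)cc1`, gives 366 nM
compound 2, `COc1ccccc1-c1ccc(S(=O)(=O)N2CCC(N3CCC(C)CC3)CC2)cc1`, gives 26 nM
compound 3, `CC1CCN(C2CCN(S(=O)(=O)c3ccc(OCc4ccccc4)cc3)CC2)CC1`, gives 385 nM

Compound 3 has the highest number of the three, but its gap to compound 1 lies within the scatter, so the two cannot be ordered. Among the compounds with values here, its gap to compound 2 is another matter: there is a 15-fold higher number from compound 2 to compound 3 (1.17 log units; beyond the scatter), the only step between measured compounds that differ in one place.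

The next compound, compound 4, `COC(=O)c1ccc(S(=O)(=O)N2CCC(N3CCC(C)CC3)CC2)cc1`, differs from compound 3 as follows: methoxycarbonyl in place of benzyloxy on an aromatic carbon. Within the data shown here, no measured step bears directly on this change. Among the measured compounds shown here, the one step available, from compound 2 to compound 3, concerns a different pair of groups at the same place, and its size shows only that the same position can shift the number well beyond the scatter. With nothing closer to lean on, the step of a 2.6-fold higher number from compound 3 to compound 4 (0.41 log units; beyond the scatter) is estimated to be modest and, if anything, toward a higher number, since compound 3 already sits at the weak end of what has been seen. Compound 4 is therefore expected to give 1000 nM, with a range from 300 nM to 4000 nM.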

Compound 4, half-maximal inhibitory concentration: > 5000 nM
Compound 4 ended at the assay's limit; the forecaster's own chance of this, stated with the estimate: 10%; middle value at least 5.0-fold (0.69 log units) away from the limit.
By their numbers in this assay, from the lowest: compound 2; then compounds 1 and 3 (each within the scatter of the next). At a limit, above all of these: compound 4.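

In this assay compound 4 gives > 5000 nM, which is a limit of the assay and not a number, so how far it lies past that point stays unknown: the limit of > 5000 nM in this assay, at which 1 of the 4 values shown sits.

Even so, the steps show that this place, on an aromatic carbon and para to a large group, can lose activity well beyond what the earlier compounds showed: methoxycarbonyl in place of benzyloxy gives an at least 12-fold higher number from compound 3 to compound 4 (1.11 log units; beyond the scatter), and methoxycarbonyl in place of 2-methoxyphenyl gives an at least 190-fold higher number from compound 2 to compound 4 (2.28 log units; beyond the scatter). Among compounds 2, 3 and 4, the two groups that carry an aromatic ring give measurable values, while methoxycarbonyl, with no ring, fewer heavy atoms and a double bond outside aromatic rings, is the one at the limit, and a single compound cannot separate these differences.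

The compounds shown leave open whether the ester itself or the absence of a ring matters, and whether an amine, a carboxylic acid or a primary amide at this place would also reach the limit. They also leave open whether a phenyl ring carrying methoxycarbonyl would bring the number back toward that of compound 2.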